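This account rests on a few compounds, and the source may have more. Where it says the series, first, only, none or still open, it means among the compounds named here.

Of the compounds shown here, three of a shared core have been measured in a functional assay on Jurkat cells for inhibition of nuclear factor NF-kappa-B complex (Homo sapiens); on this read-out higher numbers stand for weaker inhibition and lower numbers for stronger inhibition. Compound 1, `CCOC(=O)c1cnc(CC)nc1NN1C(=O)C=C(C)C1=O`, gives 10000 nM. Compound 2, `CCOC(=O)c1cnc(C(C)(C)C)nc1NN1C(=O)C=C(C)C1=O`, gives 1000 nM. Compound 3, `CCOC(=O)c1cnc(-c2cc(Cl)nc(Cl)c2)nc1NN1C(=O)C=C(C)C1=O`, gives 2000 nM, which places it second highest of the three: its nearest neighbour is compound 2 and its furthest is compound 1.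

Compound 4, `CCOC(=O)c1cnc(-c2cccc(OC)c2)nc1NN1C(=O)C=C(C)C1=O`, has not yet been measured. It differs from compound 3 in one place: 3-methoxyphenyl in place of 2,6-dichloropyridin-4-yl on an aromatic carbon.

The measured steps at this position all concern the same aromatic carbon. The change from ethyl to a larger group lowered the number twice: a 10-fold lower number from compound 1 to compound 2 (1.00 log units; beyond the scatter) and a 5.0-fold lower number from compound 1 to compound 3 (0.70 log units; beyond the scatter). The change between the two larger groups, however, was small: a 2.0-fold higher number from compound 2 to compound 3 (0.30 log units; within the scatter). Compound 4 carries a group of the same size as the one it replaces, with one aromatic ring and one acceptor in each, so the step from compound 3 to compound 4 is expected to resemble the step between compound 2 and compound 3 rather than the steps from compound 1, and no step beyond the scatter is expected, no change at the digits printed from compound 3 to compound 4 (within the scatter).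

Compound 4 is therefore estimated at 2000 nM in this assay, with a range from 700 nM to 6000 nM.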

Compound 4, half-maximal inhibitory concentration: 5000 nM
For compound 4 the middle estimate is 2.5-fold (0.40 log units) below the measured one; low and high end bracket the measured number.
By their numbers in this assay, from the lowest: compounds 2 and 3 (each within the scatter of the next); then compounds 4 and 1 (each within the scatter of the next).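

In this assay, 3-methoxyphenyl and 2,6-dichloropyridin-4-yl match in heavy atoms, aromatic rings and hydrogen-bond acceptors, yet exchanging one for the other gives a 2.5-fold higher number from compound 3 to compound 4 (0.40 log units; beyond the scatter), so these counts alone do not settle the number at this aromatic carbon. The earlier compounds shown here fitted the idea that any group larger than ethyl lowers the number, but compound 4 goes against it: the exchange of ethyl for 3-methoxyphenyl gives a 2.0-fold lower number from compound 1 to compound 4 (0.30 log units; within the scatter). Against tert-butyl the result is a 5.0-fold higher number from compound 2 to compound 4 (0.70 log units; beyond the scatter), so of the two aromatic groups only 2,6-dichloropyridin-4-yl stays within the scatter of tert-butyl.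

Nothing available gives a reason for the gap between the two aromatic groups. Still open, as far as these compounds go, is whether that gap follows the chlorine atoms, the ring nitrogen or the methoxy group, which an unsubstituted phenyl, a chlorophenyl or a pyridyl group on the same carbon would begin to separate, and how an amine or a carboxylic acid there would compare.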